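This account rests on a few compounds, and the source may have more. Where it says the series, first, only, none or still open, it means among the compounds named here.

Measured in a functional assay on SK-BR-3 cells (Homo sapiens) for inhibition, read by MTT assay; a higher number here means a weaker inhibitor of growth, a lower number a stronger inhibitor of growth:
- compound 1 `CC1=C(/C=C/C(C)=C/C=C/C(C)=C\C(=O)Nc2cccc(F)c2)C(C)(C)CCC1n1ccnc1`: 17000 nM
- compound 2 `CC1=C(/C=C/C(C)=C/C=C/C(C)=C\C(=O)NCc2ccccc2)C(C)(C)CCC1n1ccnc1`: 10700 nM

Only these two compounds have been measured, and compound 2 stands within the scatter of compound 1, so the numbers do not separate them. Compound 3 `CC1=C(/C=C/C(C)=C/C=C/C(C)=C\C(=O)NCc2ccc(F)cc2)C(C)(C)CCC1n1ccnc1` differs from compound 2 in one place: fluoro in place of hydrogen on an aromatic carbon. Going by the values given here, no measured pair isolates this change. Among the compounds with values here, the one step that bears on it, a 1.6-fold lower number from compound 1 to compound 2 (0.20 log units; within the scatter), altered the group on the amide nitrogen and stayed within the scatter. On that slim evidence, no step beyond the scatter is expected in this assay, and no direction can be favoured. Compound 3 is estimated at 10000 nM, with an expected range of 5000 nM to 20000 nM. This estimate means an expected 1.1-fold lower number from compound 2 to compound 3 (0.03 log units; within the scatter).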

Compound 3, concentration for 50% growth inhibition: 5500 nM
Beside the measured number, compound 3's estimate is 1.8-fold (0.26 log units) above it, within the range that was stated.
By their numbers in this assay, from the lowest: compounds 3, 2 and 1 (each within the scatter of the next, the first and the last beyond it).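

In this assay, fluoro in place of hydrogen on the aromatic carbon para to a large group gives a change that stays within the scatter (a 1.9-fold lower number from compound 2 to compound 3 (0.29 log units; within the scatter)), so this position on the benzyl group does not yet separate the two compounds. Going by these compounds alone, the 4-fluorobenzyl group in place of 3-fluorophenyl on the amide nitrogen does give the first step beyond the scatter in this set, though a modest one (a 3.1-fold lower number from compound 1 to compound 3 (0.49 log units; beyond the scatter)), which benzyl alone had not reached. Nothing measured here bears on the cause of either step.

From the compounds shown here alone, what chloro, methoxy or an amine at the same place on the six-membered aromatic ring would do remains open. So does whether a longer chain between the amide nitrogen and that ring would shift the number in this assay.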